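The source may report more compounds than this note shows. Statements on the series, on what has been measured and on what is new or still open speak of the compounds shown alone.

Measured compounds in an ADME assay on PC-3 cells (Homo sapiens) for cytotoxicity, read by WST assay, tested at 100 uM; on this read-out higher numbers stand for more inhibition at the one concentration tested (going by the name of the read-out) and lower numbers for less inhibition:
- Compound 1 `O=C(Nc1ccc(Cl)cn1)C1CCCN(C(=O)c2cc(C(F)(F)F)cc(C(F)(F)F)c2)C1`: compound 1 gives 0%
- Compound 2 `C=CCOc1cccc(NC(=O)C2CCCN(C(=O)c3cc(C(F)(F)F)cc(C(F)(F)F)c3)C2)c1`: compound 2 gives 0%
- Compound 3 `N#Cc1cccc(C(=O)N2CCCC(C(=O)Nc3ccc(Cl)cc3)C2)c1`: compound 3 gives 0%

Compound 3 stands level with compounds 1 and 2 on the numbers shown; its value and those of compounds 1 and 2 lie within the scatter of one another, so no order among the three can be read from them. Among the measured compounds shown here, the one measured step, no change at the digits printed from compound 1 to compound 2 (within the scatter), exchanges a group on an amide-type nitrogen and leaves the read-out unchanged within the scatter.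

The move to compound 4 `Cc1nc(-c2cccc(C(=O)N3CCCC(C(=O)Nc4ccc(Cl)cc4)C3)c2)no1` is of a different kind: 5-methyl-1,2,4-oxadiazol-3-yl in place of cyano on an aromatic carbon. For the measured compounds named here, no measured step touches this aromatic carbon, so the only guide is the flat behaviour of the series as a whole, in which compounds 1, 2 and 3 all sit at the same level. Because no change at the digits printed from compound 1 to compound 2 (within the scatter) showed no movement, and compound 3 gives 0%, the expectation is that compound 4 also shows no change beyond the scatter, that is, a step of no change at the digits printed from compound 3 to compound 4 (within the scatter). Compound 4 is therefore estimated at 0%, within a range from -10% to 15%.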

Compound 4, a percentage reported as inhibition, at one concentration (the size of the read-out at that concentration, not a potency): 0%
Compound 4: middle estimate and measured number agree at the digits printed; measured number inside the range.
By their numbers in this assay, from the lowest: compounds 1, 2, 3 and 4 (each within the scatter of the next).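

In this assay, the aromatic carbon that carries the cyano group in compound 3 gets its first reading, and the exchange of cyano for 5-methyl-1,2,4-oxadiazol-3-yl comes out as no change at the digits printed from compound 3 to compound 4 (within the scatter). The flat picture therefore now reaches a second place on the molecule, beyond the amide-type nitrogen, even though the change is a large one by count: 6 heavy atoms enter where 2 leave, as one five-membered aromatic ring with 3 hetero atoms, and 3 hydrogen-bond acceptors take the place of 1. No supporting measurement bears on this result.

As far as these compounds go, whether a primary amine or a carboxylic acid on this aromatic carbon would move the read-out away from the level shared by compound 3 and compound 4 remains open, as does the effect of a longer alkyl chain in place of the methyl on the oxadiazole. Also open, from the compounds shown here alone, is whether this level would hold at any concentration other than the single one used in this assay, since a single reading says nothing about the response at other concentrations.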